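The source may hold more compounds than are shown below. What is called first, only, known or untested is meant among the compounds shown, and "the series" means these compounds.

Measured so far in a functional assay on MCF7 cells (Homo sapiens) for inhibition, read by sulforhodamine B assay, with a stated time of 48 h; a higher number here means a weaker inhibitor of growth, a lower number a stronger inhibitor of growth
- compound 1 `CC1(/C=C/c2ccccc2)C=CC(=O)O1` gives 95300 nM
- compound 2 `CC1(/C=C/c2ccc(C(F)(F)F)cc2)C=CC(=O)O1` gives 20400 nM
- compound 3 `CC1(/C=C/c2ccccc2O)C=CC(=O)O1` gives 46200 nM

Compound 1 holds the highest number of the three. Compound 4 `CC1(/C=C/c2cccc(O)c2)C=CC(=O)O1` departs from it by hydroxy in place of hydrogen on an aromatic carbon (hydroxy in place of hydrogen on an aromatic carbon, meta to a group of 9 heavy atoms). Within the data shown here, the closest precedent is the same exchange at another place, with a 2.1-fold lower number from compound 1 to compound 3 (0.31 log units; beyond the scatter) as its modest result. The trifluoromethyl exchange, with a 4.7-fold lower number from compound 1 to compound 2 (0.67 log units; beyond the scatter) as its result, is a looser guide. Among the measured compounds shown here, no measurement yet shows what this placement does, so only a modest lowering is expected in this assay here. The expected step is a 1.9-fold lower number from compound 1 to compound 4 (0.28 log units; within the scatter) and no larger. Compound 4 is estimated at 50000 nM with 25000 nM to 100000 nM as its expected range.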

Compound 4, concentration for total growth inhibition: 124000 nM
The estimate for compound 4 lay 2.5-fold (0.39 log units) below the measured number; measured number above the stated range.
By their numbers in this assay, from the lowest: compound 2; then compound 3; then compounds 1 and 4 (each within the scatter of the next).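

The step of a 1.3-fold higher number from compound 1 to compound 4 (0.11 log units; within the scatter) for hydroxy meta to a group of 9 heavy atoms stands against a 2.1-fold lower number from compound 1 to compound 3 (0.31 log units; beyond the scatter) for the same exchange at another place on the aromatic ring. At this position, the hydroxy exchange gives no step beyond the scatter, so the earlier hydroxy result does not carry over to it. Nothing available accounts for the difference between the two places.

Still open, going by these compounds, is whether trifluoromethyl at this position would repeat a 4.7-fold lower number from compound 1 to compound 2 (0.67 log units; beyond the scatter) and whether an amine or a carboxylic acid here would move the number beyond the scatter.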